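Restoring a Free Carboxylic Acid on the Ether Tail

The compounds below may be only part of what the source reports. "The series", "measured", "known", "first", "only" and "open" are said of these compounds alone.

Measured so far in an assay on HEK293 cells for positive allosteric modulation of metabotropic glutamate receptor 2 (Rattus norvegicus), read by thallium flux, with a stated time of 2.5 min; on this read-out lower numbers stand for smaller maximal responses and higher numbers for larger maximal responses:
compound 1 `Cc1cc(OCCCCOc2ccc(C(=O)CC3CCCC3)c(O)c2C)ccc1C(=O)O` gives 83.6%
compound 2 `COC(=O)c1ccc(OCCCCOc2ccc(C(=O)CC3CCCC3)c(O)c2C)cc1` gives 12.2%

Among the compounds with values here, compound 2 stands lowest of the two numbers; its nearest neighbour is compound 1, and the one step between them, a number 71.4 percentage points lower from compound 1 to compound 2 (beyond the scatter), lies beyond the scatter. That step replaced a free carboxylic acid with its methyl ester, and the maximal response collapsed.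

Compound 3 `Cc1ccc(C(=O)O)cc1OCCCCOc1ccc(C(=O)CC2CCCC2)c(O)c1C` is still unmeasured. It differs from compound 2 in one place: 5-carboxy-2-methylphenyl in place of 4-(methoxycarbonyl)phenyl on an oxygen on a saturated carbon. The methyl ester is gone and a free carboxylic acid returns, though on a differently substituted ring than in compound 1.

Within the data shown here, the only measured step that bears on this change is a number 71.4 percentage points lower from compound 1 to compound 2 (beyond the scatter), and it was large. Reversing the ester-for-acid exchange is therefore expected to move this assay strongly upward, with the uncertainty coming from the different arrangement of the acid and methyl groups, for which no measured pair exists. The step from compound 2 to compound 3 is expected to be a number 47.8 percentage points higher from compound 2 to compound 3 (beyond the scatter). Compound 3 is estimated at 60%, within a range from 20% to 90%.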

Compound 3, largest response reached (reported as percent of maximum), in percent of the reference or control that the assay uses: 67.5%
Beside the measured number, compound 3's estimate is 7.5 percentage points below it; low and high end bracket the measured number.
By their numbers in this assay, from the lowest: compound 2; then compound 3; then compound 1.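

On the oxygen on a saturated carbon, the response in this assay does not depend on the 4-carboxy-3-methylphenyl group alone: 5-carboxy-2-methylphenyl, which carries the same atoms arranged differently, also gives a large rise over the methyl ester, with a number 55.3 percentage points higher from compound 2 to compound 3 (beyond the scatter) as the step. The arrangement on the ring still counts, since a number 16.1 percentage points lower from compound 1 to compound 3 (beyond the scatter) is a modest step but one that lies beyond the scatter, so the two acid-bearing groups are not interchangeable in this assay. Nothing measured here explains why either of these two changes alters the maximal response.

Compound 2 differs from both acids in its ester and also in having no methyl on the ring, so a 4-carboxyphenyl group, or the methyl ester of 5-carboxy-2-methylphenyl, would be needed to separate those two contributions. On these data alone, it also remains open how the response would change with a tetrazole or a primary amide in place of the carboxylic acid, or with a longer chain joining the ring to the core.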